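The source may hold more compounds than are shown below. What is called first, only, known or untested is meant among the compounds shown, and "the series" means these compounds.

Measured so far:
compound 1, `O=C(O)c1cc(-c2ccc(OCc3ccccc3)cc2)n(-c2ccccc2)n1`, > 10000 nM
compound 2, `CC(C)Oc1ccc(-c2cc(C(=O)O)nn2-c2ccc(C(C)C)cc2)cc1`, 5250 nM

Two compounds share the core of compound 2. Among the measured compounds shown here, in an assay for displacement of a labelled ligand from Apoptosis regulator Bcl-2 (Homo sapiens), read by fluorescence polarization, with a stated time of 30 min (on this read-out lower numbers stand for stronger inhibition and higher numbers for weaker inhibition), compound 2 gives 5250 nM, the only number among the two values shown. Compound 1 carries a benzyloxy group with an unsubstituted phenyl on the ring nitrogen, and its value in this assay is a limit of the assay rather than a number; it sits at the limit of > 10000 nM in this assay, at which 1 of the 2 values shown sits. For the measured compounds named here, no step between the two measured compounds can be read, as they differ in more than one place.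

Compound 3, `CC(C)c1ccc(-n2nc(C(=O)O)cc2-c2ccc(OCc3ccccc3)cc2)cc1`, is not yet measured. It keeps the isopropylphenyl of compound 2 and changes the ether: benzyl in place of isopropyl on an oxygen on an aromatic ring. Going by the values given here, the only guide is that compound 1, which also carries benzyloxy, reaches no number, while compound 2 with isopropoxy does. The expectation is therefore a step toward weaker binding, a 1.7-fold higher number from compound 2 to compound 3 (0.23 log units; within the scatter), with a real chance that compound 3 also ends at the limit. Compound 3 is estimated at 9000 nM, expected to fall between 3000 nM and 30000 nM.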

Compound 3, inhibition constant: 385 nM
The estimate for compound 3 lay 23-fold (1.37 log units) above the measured number, and the stated range ends above it.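

Among the compounds shown here, on an oxygen on an aromatic ring, the first readable step shows that benzyl in place of isopropyl gives, in this assay, a 14-fold lower number from compound 2 to compound 3 (1.13 log units; beyond the scatter), so this position takes the benzyl with a clear gain in binding. With benzyloxy kept, isopropyl in place of hydrogen on an aromatic carbon gives an at least 25-fold lower number from compound 1 to compound 3 (1.41 log units; beyond the scatter), which shows that benzyloxy without that isopropyl does not bring the series to a number, and that the two groups stand together in compound 3. Compound 1 remains a limit of the assay and not a number, so the second step has a bound rather than a fixed size: the limit of > 10000 nM in this assay, at which 1 of the 3 values shown sits.

The compounds shown leave open whether the gain rests on the aromatic ring of the benzyl or on the carbon count alone, a question that a cyclohexylmethyl group or a longer alkyl chain on the same oxygen would separate. Equally open, from the compounds shown here alone, is how a benzyl carrying a fluorine or an amine would read, and whether a tert-butyl could stand in for the isopropyl on the aromatic carbon.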